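This account rests on a few compounds, and the source may have more. Where it says the series, first, only, none or still open, it means among the compounds named here.

Measured compounds:
compound 1 `Cc1nn([C@H](C)c2ccc(Cl)cc2Cl)c2nc(N3CC[C@H](N4CCC4)[C@H](C)C3)cnc12` — 218 nM in an assay on CCRF-CEM cells for antagonist activity at C-C chemokine receptor type 4 (Homo sapiens), read by CellTiter-Glo, with stated times of 30 min and 60 min, in the presence of a further agent that is not named here; on this read-out higher numbers stand for weaker inhibition and lower numbers for stronger inhibition
compound 2 `C[C@@H]1CC(c2cnc3c(C#N)nn([C@H](C)c4ccc(Cl)cc4Cl)c3n2)=CC[C@@H]1N1CCC[C@H]1CO` — 70 nM
compound 3 `Cc1nn([C@H](C)c2ccc(Cl)cc2Cl)c2nc(C3=CC[C@H](N4CCC[C@H]4CO)[C@H](C)C3)cnc12` — 179 nM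

Among these three, compound 1 has the highest number. Its nearest neighbour is compound 3, whose number is within the scatter of that of compound 1; compound 2 lies beyond the scatter, with the lowest number of the three. Compound 4 `Cc1nn([C@H](C)c2ccc(Cl)cc2Cl)c2nc(N3CC[C@H](N4CCC[C@H]4CO)[C@H](C)C3)cnc12` has not yet been measured. It differs from compound 1 in one place: 2-(hydroxymethyl)pyrrolidin-1-yl in place of azetidin-1-yl on a saturated ring carbon.

Among the measured compounds shown here, none of the measured steps follows this change. For the measured compounds named here, the only single-point step, a 2.6-fold higher number from compound 2 to compound 3 (0.41 log units; beyond the scatter), concerns the aromatic substituent on the shared core and is modest. Compound 1 and compound 3 differ in two places, the ring that links the amine to the core and the amine itself, so their values can only be compared as they stand: they lie within the scatter of each other. The data thus give no direct measure for swapping azetidin-1-yl for 2-(hydroxymethyl)pyrrolidin-1-yl while keeping the rest of compound 1.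

The expectation for compound 4 is therefore a number close to that of compound 1, with at most a small step estimated as a 1.4-fold lower number from compound 1 to compound 4 (0.13 log units; within the scatter), in either direction and likely within the scatter. Compound 4 is estimated at 160 nM, expected to fall between 55 nM and 470 nM.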

Compound 4, half-maximal inhibitory concentration: 151 nM
For compound 4 the middle estimate is 1.1-fold (0.03 log units) above the measured one, and the stated range covers the measured number.
By their numbers in this assay, from the lowest: compound 2; then compounds 4, 3 and 1 (each within the scatter of the next).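

In this assay, among the compounds shown here, the change on the saturated ring carbon can now be read directly for the first time, and it gives a 1.4-fold lower number from compound 1 to compound 4 (0.16 log units; within the scatter). At this position, then, the swap from azetidin-1-yl to 2-(hydroxymethyl)pyrrolidin-1-yl, which brings a five-membered ring, a hydrogen-bond donor and a defined stereocentre, leaves the number within the scatter, so these two amines cannot be told apart by this read-out. No supporting measurement is available to explain this result.

With only these two amines at this position, the compounds shown cannot separate the contribution of ring size from that of the hydroxymethyl group, and it remains open how plain pyrrolidin-1-yl, morpholin-4-yl or an open-chain amine such as dimethylamino would read here. From the compounds shown here alone, it also remains open whether the opposite configuration at the hydroxymethyl-bearing carbon would give a similar number, and whether a nitrile in place of the methyl on the shared core would have the same effect on the core of compound 4 as in a 2.6-fold higher number from compound 2 to compound 3 (0.41 log units; beyond the scatter), read in the reverse direction.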